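Swapping an aryl group for a sulfonamide on a cytotoxicity core

This account rests on a few compounds, and the source may have more. Where it says the series, first, only, none or still open, it means among the compounds named here.

Measured so far:
compound 1, `O=C1O/C(=C\Cn2cc(-c3cc(F)cc(F)c3)nn2)C(OCc2ccccc2)=C1OCc1ccccc1`, > 100000 nM
compound 2, `COc1ccccc1-c1cn(C[C@H](O)[C@H]2OC(=O)C(OCc3ccccc3)=C2OCc2ccccc2)nn1`, 50 nM

Of the compounds shown here, two have been tested in an ADME assay on HFF cells (Homo sapiens) for cytotoxicity, read by MTT assay, with a stated time of 72 h; on this read-out higher numbers stand for weaker inhibition and lower numbers for stronger inhibition. Compound 1 gives only a limit of the assay, > 100000 nM, as noted in the limit of > 100000 nM in this assay, at which 1 of the 2 values shown sits. Compound 2 gives 50 nM, the only plain number shown, so it stands as the sole reference point for the shared core.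

Compound 3, `Cc1ccc(S(=O)(=O)NCc2cn(C[C@H](O)[C@H]3OC(=O)C(OCc4ccccc4)=C3OCc3ccccc3)nn2)cc1`, has not been measured. It differs from compound 2 in one place: (((4-methylphenyl)sulfonyl)amino)methyl in place of 2-methoxyphenyl on an aromatic carbon.

Among the measured compounds shown here, no step between two measured compounds is available to guide the expectation, so the estimate rests on the value of compound 2 alone and on the size of the change. The step of a 30-fold higher number from compound 2 to compound 3 (1.48 log units; beyond the scatter) is expected to run toward weaker inhibition and to lie beyond the usual scatter. Compound 3 is therefore estimated at 1500 nM, with a likely range from 200 nM to 20000 nM.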

Compound 3, half-maximal inhibitory concentration: 50 nM
Compound 3: middle estimate off by 30-fold (1.48 log units), on the high side, and the stated range ends above it.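

In this assay, replacing 2-methoxyphenyl with (((4-methylphenyl)sulfonyl)amino)methyl gives no change at the digits printed from compound 2 to compound 3 (within the scatter), so this aromatic carbon of the five-membered ring accepts a very different group with no readable shift. The entering group brings a sulfur, a nitrogen and a hydrogen-bond donor that 2-methoxyphenyl lacks, yet the two compounds read alike, something the earlier pair could not show without a step linking them. Nothing measured here explains why the two groups read alike.

From the compounds shown here alone, whether a simple amine or a carboxylic acid on this carbon would read the same remains open. Among the compounds shown here, compound 1 gives only a limit of the assay, > 100000 nM, and with no single-place step linking it to the others, what separates it from them also remains open.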